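Pyrrolidinyl in Place of an Acyclic Amine on the Thiocarbonyl

The source may report more compounds than this note shows. Statements on the series, on what has been measured and on what is new or still open speak of the compounds shown alone.

Of the compounds shown here, three sharing one core have been measured in a functional assay on A-375 cells (Homo sapiens) for antiproliferative activity, read by CCK-8 assay, with a stated time of 72 h, tested at 8 uM; a higher number here means a stronger effect of the compound at the concentration tested, a lower number a weaker effect. Compound 1 `CN(C(=S)SCc1ccc(C(=O)Nc2ccccc2N)cc1)c1cccnc1` gives 87.7%; compound 2 `CC1CCN(C(=S)SCc2ccc(C(=O)Nc3ccccc3N)cc2)CC1` gives 87.4%; compound 3 `CN(Cc1ccncc1)C(=S)SCc1ccc(C(=O)Nc2ccccc2N)cc1` gives 86.1%. Compound 3 thus holds the lowest of the three numbers, yet both of its neighbours lie within the scatter of it: the step of a number 1.6 percentage points lower from compound 1 to compound 3 (within the scatter) and the step of a number 1.3 percentage points lower from compound 2 to compound 3 (within the scatter) are both small, as is the step of a number 0.3 percentage points lower from compound 1 to compound 2 (within the scatter).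

Compound 4 `Nc1ccccc1NC(=O)c1ccc(CSC(=S)N2CCCC2)cc1` is not yet measured. It differs from compound 3 in one place: pyrrolidin-1-yl in place of methyl((pyridin-4-yl)methyl)amino on a thiocarbonyl carbon. Going by the values given here, the steps that bear on this are those in which the group on the thiocarbonyl carbon changed, namely a number 0.3 percentage points lower from compound 1 to compound 2 (within the scatter) and a number 1.3 percentage points lower from compound 2 to compound 3 (within the scatter), where a cyclic amine and an acyclic amine were exchanged without any step beyond the scatter. Compound 4 is therefore expected to show no step beyond the scatter, a number 0.1 percentage points lower from compound 3 to compound 4 (within the scatter). In this assay compound 4 is estimated at 86%, within a range from 76% to 93%.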

Compound 4, a percentage reported as inhibition, at one concentration (the size of the read-out at that concentration, not a potency): 89.5%
Beside the measured number, compound 4's estimate is 3.5 percentage points below it, within the range that was stated.
By their numbers in this assay, from the lowest: compounds 3, 2, 1 and 4 (each within the scatter of the next).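

In this assay, the thiocarbonyl carbon also accepts pyrrolidin-1-yl, a five-membered non-aromatic ring, with a number 3.4 percentage points higher from compound 3 to compound 4 (within the scatter). Going by these compounds alone, the comparisons with the other two groups give the same reading, with a number 2.1 percentage points higher from compound 2 to compound 4 (within the scatter) and a number 1.8 percentage points higher from compound 1 to compound 4 (within the scatter), so this ring size joins the earlier groups without any step beyond the scatter, and the exchange for methyl((pyridin-4-yl)methyl)amino removes a six-membered aromatic ring and a hydrogen-bond acceptor with no such step. No measurement shown here accounts for these numbers.

On these data alone, all four compounds were read at one concentration, so any difference in potency among them remains open. It is also open whether a morpholine ring, a carboxylic acid or a longer alkyl chain on the thiocarbonyl carbon would stay within the scatter of these compounds.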